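The source may hold more compounds than are shown below. What is called first, only, known or untested is meant among the compounds shown, and "the series" means these compounds.

Working notes on the series. For the measured compounds named here, in a physicochemical assay, with a stated time of 30 min (on this read-out lower numbers stand for stronger inhibition and higher numbers for weaker inhibition), compound 2 `CCOc1cc(/C=N/NC(=O)c2ccc(OCc3cc(OC)c(OC)c(OC)c3)cc2)ccc1O` gives 106 ug/mL, the only actual number so far. Compound 1 `COc1cc(COc2ccc(C(=O)N/N=C/c3cc(Br)cc(Cl)c3O)cc2)cc(OC)c1OC` reports > 100 ug/mL, which is a limit and not a number. The other reading in the series is therefore (the limit of > 100 ug/mL in this assay, at which 1 of the 2 values shown sits).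

The next structure is compound 3 `COc1cc(/C=N/NC(=O)c2ccc(OCc3cc(OC)c(OC)c(OC)c3)cc2)cc(OC)c1OC`, where 3,4,5-trimethoxyphenyl stands in place of 3-ethoxy-4-hydroxyphenyl on a carbon with a double bond to nitrogen (3,4,5-trimethoxyphenyl in place of 3-ethoxy-4-hydroxyphenyl on a carbon with a double bond to nitrogen). Going by the values given here, the only measured step at this place is a step that the limit leaves unreadable from compound 1 to compound 2, and it offers neither a size nor a direction to carry over. Among the compounds with values here, the sole numeric reference is compound 2 at 106 ug/mL, so no change beyond the scatter is expected in this assay. The expected step is a 1.0-fold higher number from compound 2 to compound 3 (0.02 log units; within the scatter). For compound 3 the estimated value is 110 ug/mL, with an expected range of 50 ug/mL to 240 ug/mL.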

Compound 3, half-maximal inhibitory concentration: > 100 ug/mL
Compound 3 ended at the assay's limit (the forecaster's own chance of this, stated with the estimate: 40%); the middle value does not contradict the limit.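

In this assay, for the compounds shown here, compound 3 gives > 100 ug/mL, a limit and not a number, so no step among compound 1, compound 2 and compound 3 can be read. Open remains how far 3,4,5-trimethoxyphenyl or 5-bromo-3-chloro-2-hydroxyphenyl differs from 3-ethoxy-4-hydroxyphenyl in this assay.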